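Replacing 3-Methoxyphenyl with 4-Iodophenyl: What to Expect

This account rests on a few compounds, and the source may have more. Where it says the series, first, only, none or still open, it means among the compounds named here.

Compound 1 `Cc1ccc2nc(NC(c3cn(-c4ccccc4)nc3-c3cccc(Cl)c3)c3c(O)ccc4ccccc34)sc2c1`: 45400 nM
Compound 2 `Cc1cc2nc(NC(c3cn(-c4ccccc4)nc3-c3ccc([N+](=O)[O-])cc3)c3c(O)ccc4ccccc34)sc2cc1C`: 41900 nM
Compound 3 `COc1cccc(-c2nn(-c3ccccc3)cc2C(Nc2nc3ccccc3s2)c2c(O)ccc3ccccc23)c1`: 24800 nM

All three values come from a functional assay on A549 cells (Homo sapiens) for antiproliferative activity, read by MTT assay, with a stated time of 48 h; on this read-out lower numbers stand for stronger inhibition and higher numbers for weaker inhibition. Compound 3, at 24800 nM, has the lowest number shown, but it lies within the usual scatter of both other compounds, so the three cannot truly be ranked.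

The next compound to be tested is compound 4 `Oc1ccc2ccccc2c1C(Nc1nc2ccccc2s1)c1cn(-c2ccccc2)nc1-c1ccc(I)cc1`. It differs from compound 3 in one place: 4-iodophenyl in place of 3-methoxyphenyl on an aromatic carbon. In words, 4-iodophenyl stands in place of 3-methoxyphenyl on an aromatic carbon.

Among the measured compounds shown here, no two measured compounds differ in one place only, so the data offer no direct guide to this swap. Still, compound 1 at 45400 nM and compound 2 at 41900 nM carry other changes and remain within the scatter of compound 3. No shift beyond the scatter is therefore expected in this assay, and the expected size is a 1.2-fold higher number from compound 3 to compound 4 (0.08 log units; within the scatter). For compound 4 the estimated value is 30000 nM, with an expected range from 12000 nM to 70000 nM.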

Compound 4, half-maximal inhibitory concentration: 23100 nM
Beside the measured number, compound 4's estimate is 1.3-fold (0.11 log units) above it; the measured number falls inside the stated range.
By their numbers in this assay, from the lowest: compounds 4, 3, 2 and 1 (each within the scatter of the next).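

Among the compounds shown here, compound 3 and compound 4 form the first pair here that differs in one place only, which gives the first direct reading of a change on this aromatic carbon of the five-membered ring. In this assay, the step is a 1.1-fold lower number from compound 3 to compound 4 (0.03 log units; within the scatter), so the two compounds cannot be told apart, even though a group with a hydrogen-bond acceptor gives way to one without. No measured information is available to account for this result.

Both groups in this comparison are substituted phenyl rings, so one pair says little about the position as a whole. From the compounds shown here alone, it remains open whether an amine or a carboxylic acid on that phenyl ring, or a longer chain in place of the ring, would give a step beyond the scatter.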